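The source may hold more compounds than are shown below. What is called first, only, known or untested is meant among the compounds shown, and "the series" means these compounds.

Measured compounds:
compound 1, `N=C(NCc1ccccc1)[C@@H]1CCC(=O)N1Cc1ccc(F)cc1`: 31.4%
compound 2, `N=C(NCc1ccc(O)cc1)[C@@H]1CCC(=O)N1Cc1ccc(F)cc1`: 48.6%
compound 3, `Cc1ccc(CN2C(=O)CC[C@H]2C(=N)NCc2ccccc2)cc1`: 24.8%

Three compounds of one series were tested in a functional assay on SH-SY5Y cells (Homo sapiens) for cytotoxicity, read by MTT assay, with stated times of 8 h, 30 min and 12 h, tested at 5 uM; a lower number here means a weaker effect, a higher number a stronger effect of the compound at the concentration tested. Compound 1 `N=C(NCc1ccccc1)[C@@H]1CCC(=O)N1Cc1ccc(F)cc1` gives 31.4% in this assay. Compound 2 `N=C(NCc1ccc(O)cc1)[C@@H]1CCC(=O)N1Cc1ccc(F)cc1` gives 48.6%, and compound 3 `Cc1ccc(CN2C(=O)CC[C@H]2C(=N)NCc2ccccc2)cc1` gives 24.8%.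

Compound 2 differs from compound 1 by hydroxy in place of hydrogen on an aromatic carbon. This change brought a number 17.2 percentage points higher from compound 1 to compound 2 (beyond the scatter). Compound 3 differs from compound 1 by methyl in place of fluoro on an aromatic carbon, and that change brought a number 6.6 percentage points lower from compound 1 to compound 3 (within the scatter). The values of compound 2 and compound 3 differ by more than the scatter, so compound 3 stands clearly under compound 2 in this assay.

Compound 4 `Cc1ccc(CN2C(=O)CC[C@H]2C(=N)NCc2ccc(O)cc2)cc1` has not yet been measured. It differs from compound 3 by hydroxy in place of hydrogen on an aromatic carbon. This is the same change that was seen between compound 1 and compound 2, made on the core of compound 3 instead of the core of compound 1. The two cores differ by methyl in place of fluoro on an aromatic carbon.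

Among the compounds with values here, since only one example of this change is available, the expectation for compound 4 rests on it alone. For compound 4 the step of a number 17.2 percentage points higher from compound 3 to compound 4 (beyond the scatter) is expected, because the corresponding step was a number 17.2 percentage points higher from compound 1 to compound 2 (beyond the scatter). Compound 4 is therefore estimated at 42% in this assay. The lower end of the estimate for compound 4 is 30%. The upper end of the estimate for compound 4 is expected to be 55%.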

Compound 4, a percentage reported as activity, at one concentration (the size of the read-out at that concentration, not a potency): 23.8%
Estimate against measurement, compound 4: 18.2 percentage points above; measured number outside the range, below it.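

Placed on the core of compound 3, hydroxy in place of hydrogen gave a number 1 percentage points lower from compound 3 to compound 4 (within the scatter), so the rise seen on the core of compound 1 did not carry over to this second core in this assay: the same change on two cores in this assay, a number 17.2 percentage points higher (beyond the scatter) from compound 1 to compound 2 and a number 1 percentage points lower (within the scatter) from compound 3 to compound 4, 18.2 percentage points apart, beyond the scatter of two such steps. The same four compounds read the other way tell the same story, since methyl in place of fluoro, which stayed within the scatter on the pair without hydroxy, gave a number 24.8 percentage points lower from compound 2 to compound 4 (beyond the scatter) on the pair carrying 4-hydroxybenzyl: the same change on two cores in this assay, a number 6.6 percentage points lower (within the scatter) from compound 1 to compound 3 and a number 24.8 percentage points lower (beyond the scatter) from compound 2 to compound 4, 18.2 percentage points apart, beyond the scatter of two such steps. The effect of the hydroxy group in this series therefore depends on the group at the other end of the molecule, but this rests on a single set of four compounds at one concentration, and it does not show how that dependence arises or how far it extends beyond fluoro and methyl.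

Going by these compounds, whether another group in place of hydroxy on the benzyl ring, such as an amine, a methoxy group or a carboxylic acid, would also depend on the core stays open. So does the outcome with chloro in place of fluoro or methyl, or with a longer chain in place of benzyl.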